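The compounds below may be only part of what the source reports. "The series", "measured", "known", "first", "only" and "open" are said of these compounds alone.

Measured so far in a functional assay on PC-12 cells (Rattus norvegicus) for inhibition, read by sulforhodamine B assay; on this read-out higher numbers stand for weaker inhibition and lower numbers for stronger inhibition:

- Compound 1 `O=C1NC(=O)C(Cc2ccc(OCC3CCC3)cc2)S1`: > 100000 nM
- Compound 2 `O=C1NC(=O)/C(=C/c2ccc(OCC3CC3)cc2)S1`: 23000 nM

Compound 1 has no true number on this scale. Its entry of > 100000 nM is a limit of the assay and not a measured value, and it is the limit of > 100000 nM in this assay, at which 1 of the 2 values shown sits. Among the compounds with values here, compound 2, at 23000 nM, is the only one of the pair with a number.

The next compound is compound 3 `O=C1NC(=O)C(Cc2ccccc2)S1`, which has hydrogen in place of cyclobutylmethoxy on an aromatic carbon. The cyclobutylmethoxy group is therefore gone, while the rest of compound 1 stays the same. Within the data shown here, no step between measured compounds offers a direct guide to the size of this change. In this assay, no step beyond the usual scatter is expected, and no firm direction can be assigned. Compound 3 may well return a limit too. The estimated change is a number no higher from compound 1 to compound 3 (the limit leaves the size open). For compound 3 the estimated value is 100000 nM, with an expected range of 30000 nM to 300000 nM.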

Compound 3, half-maximal inhibitory concentration: > 100000 nM
Compound 3 ended at the assay's limit; the forecaster's own chance of this, stated with the estimate: 70%; the middle value lies on the limit itself.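

Compound 1 and compound 3 each give only a limit and no number in this assay, so no step can be read between them: the limit of > 100000 nM in this assay, at which 2 of the 3 values shown sit.

The compounds shown leave open whether replacing cyclobutylmethoxy with hydrogen changes inhibition at all, and in which direction any such change would run.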